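Removing the Bromo Group from Compound 2

The compounds below may be only part of what the source reports. "The series", "measured", "known", "first", "only" and "open" are said of these compounds alone.

Measured compounds:
- compound 1 `COC(=O)c1ccc(C)cc1OC(=O)COc1cc(O)c2c(=O)cc(-c3ccccc3)oc2c1`: 31100 nM
- compound 2 `COC(=O)c1cc(Br)ccc1OC(=O)COc1cc(O)c2c(=O)cc(-c3ccccc3)oc2c1`: 780 nM

These two compounds share a core and differ only in the group attached to the oxygen next to a carbonyl group. In a functional assay on cells (T-cell, Mus musculus, strain BALB/c) for inhibition, read by MTT assay, with a stated time of 72 h (on this read-out lower numbers stand for stronger inhibition and higher numbers for weaker inhibition), compound 1 gives 31100 nM, while compound 2 gives 780 nM. Compound 2 therefore stands lowest of the two numbers, its nearest neighbour being compound 1, with a 40-fold lower number from compound 1 to compound 2 (1.60 log units; beyond the scatter).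

Compound 3 `COC(=O)c1ccccc1OC(=O)COc1cc(O)c2c(=O)cc(-c3ccccc3)oc2c1` has not been measured. It differs from compound 2 as follows: hydrogen in place of bromo on an aromatic carbon. For the measured compounds named here, the only measured step that bears on this part of the molecule is a 40-fold lower number from compound 1 to compound 2 (1.60 log units; beyond the scatter), which shows that a change on this ring can move the number a great deal, but it does not isolate the bromo group alone, since the methyl group of compound 1 sits elsewhere on the ring. Removing the bromo group is expected to push the number upward, back toward compound 1, though probably not all the way; the step expected is a 6.4-fold higher number from compound 2 to compound 3 (0.81 log units; beyond the scatter). Compound 3 is thus estimated at 5000 nM, within a range of 1200 nM to 25000 nM.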

Compound 3, half-maximal inhibitory concentration: 28500 nM
For compound 3 the middle estimate is 5.7-fold (0.76 log units) below the measured one, and the stated range ends below it.
By their numbers in this assay, from the lowest: compound 2; then compounds 3 and 1 (each within the scatter of the next).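

In this assay, removing the bromo group gives a 37-fold higher number from compound 2 to compound 3 (1.56 log units; beyond the scatter), so the low number of compound 2 goes with the bromo group itself, on the aromatic carbon para to a large group and meta to a methoxycarbonyl group, and the unsubstituted ring of compound 3 does not share it. The methyl group of compound 1 adds nothing that can be told apart from plain hydrogen, as a 1.1-fold lower number from compound 1 to compound 3 (0.04 log units; within the scatter) shows, so the large step between compound 1 and compound 2 reflects the arrival of the bromo group rather than the loss of the methyl group. Nothing available explains why this one atom matters so much in this cell read-out.

The compounds shown leave open whether the effect is specific to bromo or would also appear with chloro or iodo on the same carbon, or with a quite different group there, such as an amine or a carboxylic acid. They also leave open whether a bromo group on another carbon of this ring would give a similarly low number.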